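The source may hold more compounds than are shown below. What is called first, only, known or untested is meant among the compounds shown, and "the series" means these compounds.

Measured in an ADME assay on HEp-2 cells (Homo sapiens) for cytotoxicity; a higher number here means that more compound is tolerated, a lower number that less compound is tolerated:
- compound 1 `CC(C)CCn1c(Cn2c(=O)n(C(C)C)c3ccccc32)nc2c(CN)cccc21`: 7000 nM
- compound 2 `CC(C)CCn1c(Cn2c(=O)n(C(C)C)c3ccccc32)nc2cc(CN(C)C)ccc21`: 5650 nM

Among the compounds with values here, compound 1 at 7000 nM and compound 2 at 5650 nM lie within the scatter of each other, so compound 1 stands level with the only other measured compound. Compound 3 `CC(C)CCn1c(Cn2c(=O)n(C(C)C)c3ccccc32)nc2c(CCCN)cccc21` keeps the core of compound 1 and carries 2-aminoethyl in place of amino on a saturated chain carbon bound to an aromatic carbon. The same difference, cut one bond further out, reads aminomethyl to 3-aminopropyl.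

Within the data shown here, no measured pair isolates a single change, so the data offer no direct guide to this one. In this assay, only a small move towards a lower number is expected, possibly none beyond the scatter. The expected change is a 1.4-fold lower number from compound 1 to compound 3 (0.15 log units; within the scatter). Compound 3 is estimated at 5000 nM, with an expected range of 2200 nM to 11000 nM.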

Compound 3, half-maximal cytotoxic concentration: 2340 nM
Compound 3: middle estimate off by 2.1-fold (0.33 log units), on the high side; the range from low to high includes it.
By their numbers in this assay, from the lowest: compound 3; then compounds 2 and 1 (each within the scatter of the next).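

In this assay, within the data shown here, the position proves sensitive to chain length: 2-aminoethyl in place of amino on a saturated chain carbon bound to an aromatic carbon gives a 3.0-fold lower number from compound 1 to compound 3 (0.48 log units; beyond the scatter) and provides the first single-change step. Read one bond further out, the move from aminomethyl to 3-aminopropyl shifts the number beyond the scatter, towards less compound being tolerated, although the step is only modest. Nothing measured here accounts for this step.

As far as these compounds go, whether the number falls steadily with chain length remains open, and a 2-aminoethyl group in place of aminomethyl would provide the intermediate case. Also open, from the compounds shown here alone, is whether the terminal primary amine matters at this length, a question that a dimethylamine or a carboxylic acid at the chain end would test.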